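Stripping the sulfonamide nitrogen of compound 2

This account rests on a few compounds, and the source may have more. Where it says the series, first, only, none or still open, it means among the compounds named here.

Measured in a functional assay on UO-31 cells (Homo sapiens) for antiproliferative activity, read by sulforhodamine B assay, with a stated time of 72 h; on this read-out higher numbers stand for weaker inhibition and lower numbers for stronger inhibition:
- Compound 1 (`Fc1ccc(Nc2nncc3ccccc23)cc1`): 4.7 nM
- Compound 2 (`Cc1cc(NS(=O)(=O)c2ccc(Nc3nncc4ccccc34)cc2)no1`): 33 nM

Only these two compounds have been measured so far, and they differ in more than one place. Compound 2 holds the higher of the two numbers, and so the weaker inhibition, with compound 1 lying below it by more than the usual scatter.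

The next compound, compound 3 (`NS(=O)(=O)c1ccc(Nc2nncc3ccccc23)cc1`), puts hydrogen in place of 5-methyl-1,2-oxazol-3-yl on a sulfonamide nitrogen. It keeps the sulfonamide but loses the ring attached to it.

Going by the values given here, no measured pair isolates this change, so any forecast for this assay is loose. Among the compounds with values here, the only guide is compound 1 at 4.7 nM, which is also smaller than compound 2 and has the lower number. A modest move towards stronger inhibition therefore seems more likely than a loss, though a result within the scatter would be no surprise. The expected step is a 2.2-fold lower number from compound 2 to compound 3 (0.34 log units; beyond the scatter). The estimate for compound 3 is 15 nM, with an expected range of 4 nM to 60 nM.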

Compound 3, half-maximal inhibitory concentration: 23 nM
For compound 3 the middle estimate is 1.5-fold (0.19 log units) below the measured one, within the range that was stated.
By their numbers in this assay, from the lowest: compound 1; then compounds 3 and 2 (each within the scatter of the next).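

In this assay, the step on taking the 5-methyl-1,2-oxazol-3-yl group off the sulfonamide nitrogen is a 1.4-fold lower number from compound 2 to compound 3 (0.16 log units; within the scatter), so the two compounds cannot be told apart and the ring makes no readable difference at this position. The larger gap lies in the other change, sulfamoyl in place of fluoro on an aromatic carbon, where the step is a 4.9-fold higher number from compound 1 to compound 3 (0.69 log units; beyond the scatter) and stands beyond the scatter, so a sulfonamide with a bare nitrogen still does not reach the number held by the fluoro compound. Nothing is available here to explain either result.

The compounds shown leave open whether any other substituent on the sulfonamide nitrogen, such as a methyl or an acetyl group, would move the number beyond the scatter, since only hydrogen and one ring have been compared there. They also leave open how a carboxylic acid or a simple amine would compare with fluoro and sulfamoyl on that aromatic carbon.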